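A few compounds are considered here, and "the series" means these few. Any claim that something is new, unique, unknown or untested is made for them only; others in the source may bear on it.

Measured so far in a functional assay, tested at 100 ug/mL; a lower number here means a weaker effect, a higher number a stronger effect of the compound at the concentration tested:
- compound 1, `N#CC1=C(N)OC(c2c[nH]c3ccccc23)=C(C#N)C1c1ccccc1`: 19.3%
- compound 2, `N#CC1=C(N)OC(c2c[nH]c3ccccc23)=C(C#N)C1c1ccc2ccccc2c1`: "not active" (no number reported)
- compound 3, `COc1ccc(C2C(C#N)=C(N)OC(c3c[nH]c4ccccc34)=C2C#N)cc1OC`: 19.1%

Compound 1 has the highest of the two numbers in this assay, but its nearest neighbour, compound 3, sits only a small distance away: the step of a number 0.2 percentage points lower from compound 1 to compound 3 (within the scatter) lies within the scatter, so the two cannot be told apart. Compound 2 gave no number at all.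

The unmeasured compound 4, `Cc1ccccc1C1C(C#N)=C(N)OC(c2c[nH]c3ccccc23)=C1C#N`, differs from compound 1 in one place: methyl in place of hydrogen on an aromatic carbon. Going by the values given here, only one measured step touches the same part of the shared core, the swap of phenyl for 3,4-dimethoxyphenyl from compound 1 to compound 3, and it made no difference beyond the scatter. Compound 2 shows that a much larger change at this position can remove the activity entirely, but methyl is a far smaller addition. A step of about a number 2.3 percentage points lower from compound 1 to compound 4 (within the scatter) is therefore expected, essentially none beyond the scatter. Compound 4 is estimated at 17%, within a range from 5% to 28%.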

Compound 4, a percentage reported as activity, at one concentration (the size of the read-out at that concentration, not a potency): 17.2%
The estimate for compound 4 lay 0.2 percentage points below the measured number; low and high end bracket the measured number.
By their numbers in this assay, from the lowest: compounds 4, 3 and 1 (each within the scatter of the next).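

The step of a number 2.1 percentage points lower from compound 1 to compound 4 (within the scatter) in this assay shows that the phenyl ring tolerates a methyl on an aromatic carbon, ortho to a large group, with no change that can be told from the scatter. Going by these compounds alone, until now, the only number-bearing change to this phenyl had been 3,4-dimethoxyphenyl, so this is the first sign that a group in this place also leaves the read-out intact, and the step of a number 1.9 percentage points lower from compound 3 to compound 4 (within the scatter) shows that the two substituted phenyl groups cannot be told apart either. No measured property of these compounds bears on this result, so it comes without an explanation.

Still open, going by these compounds, is whether a larger or different group in this place, such as an amine, a carboxylic acid or a longer chain, would leave the read-out equally unmoved. Also open is why compound 2 gave no number, while the compounds with single-ring groups here all did.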